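The source may hold more compounds than are shown below. What is called first, only, known or untested is meant among the compounds shown, and "the series" means these compounds.

Working notes on the series in an assay on CHO cells for positive allosteric modulation of metabotropic glutamate receptor 5 (Homo sapiens), read by FLIPR; on this read-out lower numbers stand for an effect already at smaller amounts and higher numbers for an effect only at larger amounts of compound. Compound 2, `COc1ccccc1C(=O)Nc1ccc(Cl)cc1CN1C(=O)c2ccccc2C1=O`, gives only a limit in this assay, > 100000 nM, and no number. Compound 1, `COc1ccc2c(c1OC)C(=O)N(Cc1cc(Cl)ccc1NC(=O)c1ccccn1)C2=O`, also sits at a limit in this assay, > 100000 nM. Compound 3, `CCOc1cccc2c1C(=O)N(Cc1cc(Cl)ccc1NC(=O)c1ccccn1)C2=O`, gives 280 nM in this assay. Compound 2 thus stands at the limit of > 100000 nM in this assay, at which 2 of the 3 values shown sit, and no number places it against compound 3. Compound 4, `O=C(Nc1ccc(Cl)cc1CN1C(=O)c2ccccc2C1=O)c1cccnc1`, differs from compound 2 by pyridin-3-yl in place of 2-methoxyphenyl on a carbonyl carbon. Among the compounds with values here, no measured pair covers this change, so the direction rests on compound 2 alone. The step is expected to be none beyond the scatter, reading an at least 1.2-fold lower number from compound 2 to compound 4 (0.09 log units; that floor lies within the scatter). Compound 4 is expected at 80000 nM in this assay, within 20000 nM to 300000 nM, most likely reported again as a limit.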

Compound 4, half-maximal effective concentration: 35000 nM
Compound 4: middle estimate off by 2.3-fold (0.36 log units), on the high side; the range from low to high includes it.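

Within the data shown here, on a carbonyl carbon whose other neighbours are an amide-type nitrogen, pyridin-3-yl in place of 2-methoxyphenyl gives the first readable step in this assay: an at least 2.8-fold lower number from compound 2 to compound 4 (0.45 log units; beyond the scatter). Among these compounds, this position therefore responds to the group it carries, which the earlier compounds could not show. The true size of the step stays unknown, since compound 2 gives only a limit: the limit of > 100000 nM in this assay, at which 2 of the 4 values shown sit.

Still open, from the compounds shown here alone, is whether a piperidine or a longer alkyl chain on this carbonyl carbon would lower the number further. Also open, going by these compounds, is whether the same change would carry over to the core of compound 3.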